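A few compounds are considered here, and "the series" means these few. Any claim that something is new, unique, unknown or untested is made for them only; others in the source may bear on it.

Measured so far:
compound 1, `O=C(O)CCCO/N=c1/ccn([C@@H]2O[C@H](COP(=O)(O)OP(=O)(O)OP(=O)(O)O)[C@@H](O)[C@H]2O)c(=O)[nH]1`, 697 nM in a functional assay on 1321-N1 cells for agonist activity at P2Y purinoceptor 6 (Homo sapiens), read by scintillation counting and inositol phosphate accumulation; a higher number here means that more compound is needed for the effect, a lower number that less compound is needed
compound 2, `O=c1[nH]/c(=N\OCCCCc2ccccc2)ccn1[C@@H]1O[C@H](COP(=O)(O)OP(=O)(O)OP(=O)(O)O)[C@@H](O)[C@H]1O`, 251 nM

Compound 2 gives the lowest of the two numbers shown; its nearest neighbour is compound 1, reached by the single step of a 2.8-fold lower number from compound 1 to compound 2 (0.44 log units; beyond the scatter). The unmeasured compound 3, `O=c1[nH]/c(=N\OCCOc2ccccc2)ccn1[C@@H]1O[C@H](COP(=O)(O)OP(=O)(O)OP(=O)(O)O)[C@@H](O)[C@H]1O`, differs from compound 2 by phenoxy in place of phenethyl on a saturated chain carbon, two bonds along the chain from an oxygen. For the measured compounds named here, no measured step bears on this change directly. Going by the values given here, the one step known, from compound 1 to compound 2, swaps a carboxy for a benzyl and is modest in size; it says that the chain end tolerates an aromatic ring, but nothing about shortening the chain or adding an oxygen in it. Compound 3 is therefore expected to stay within a small step of compound 2, perhaps toward a somewhat higher number, a 1.6-fold higher number from compound 2 to compound 3 (0.20 log units; within the scatter). Compound 3 is estimated at 400 nM, in the range 150 nM to 1200 nM.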

Compound 3, half-maximal effective concentration: 1780 nM
Estimate against measurement, compound 3: 4.5-fold (0.65 log units) below; the measured number lies above the stated range.
By their numbers in this assay, from the lowest: compound 2; then compound 1; then compound 3.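

In this assay, replacing 4-phenylbutyl with 2-phenoxyethyl at the chain end gives a 7.1-fold higher number from compound 2 to compound 3 (0.85 log units; beyond the scatter), so an aromatic ring at the end of the chain does not by itself keep the number low. Against the carboxy-ended chain, the phenoxy-ended chain gives a 2.6-fold higher number from compound 1 to compound 3 (0.41 log units; beyond the scatter), which places the ring-bearing compound 3 on the opposite side of compound 1 from the ring-bearing compound 2. Nothing available explains this rise.

The change alters the chain length and puts an oxygen into the chain at once, and the compounds shown do not separate these two parts. Going by these compounds, a 3-phenoxypropyl chain, or an amine in place of the chain oxygen, would bear on that question, and how either would read remains open.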